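This account rests on a few compounds, and the source may have more. Where it says the series, first, only, none or still open, it means among the compounds named here.

Measured compounds in an assay on cells for antagonist activity at D(4) dopamine receptor (Homo sapiens), read by luminescence and beta-arrestin recruitment, with a stated time of 90 min; a lower number here means a stronger inhibitor, a higher number a weaker inhibitor:

Compound 1, `Cc1cccc(NC(=O)CCN2CCN(c3ccccn3)CC2)c1`, gives 1090 nM.
Compound 2, `Cc1cccc(NC(=O)CCN2CCN(c3ncccn3)CC2)c1`, gives 430 nM.
Compound 3, `Cc1cccc(NC(=O)CN2CCN(c3ncccn3)CC2)c1`, gives 197 nM.

Compound 3 has the lowest number of the three in this assay; its nearest neighbour is compound 2, and compound 1 lies furthest from it. Compounds 2 and 1 share a core and differ in one place: pyridin-2-yl in place of pyrimidin-2-yl on an amine nitrogen in a ring. That change gave a 2.5-fold higher number from compound 2 to compound 1 (0.40 log units; beyond the scatter), a step beyond the usual scatter. The difference between the core of compound 2 and the core of compound 3 is not broken down here; what the two values show is that compound 3 sits lower than compound 2 in this assay by a margin beyond the scatter.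

Compound 4, `Cc1cccc(NC(=O)CN2CCN(c3ccccn3)CC2)c1`, has not yet been measured. It is related to compound 3 by pyridin-2-yl in place of pyrimidin-2-yl on an amine nitrogen in a ring, the same kind of change as that from compound 2 to compound 1, made at the same place. Among the compounds with values here, only one example of this change has been measured among the compounds here, so the expectation rests on a single step. The step from compound 3 to compound 4 in this assay is expected to be about a 2.5-fold higher number from compound 3 to compound 4 (0.40 log units; beyond the scatter), because the measured step of a 2.5-fold higher number from compound 2 to compound 1 (0.40 log units; beyond the scatter) points in that direction and the same group leaves and the same group enters at the same place. Compound 4 is therefore estimated at 490 nM, with a likely range from 250 nM to 1000 nM.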

Compound 4, half-maximal inhibitory concentration: 313 nM
Beside the measured number, compound 4's estimate is 1.6-fold (0.19 log units) above it; measured number inside the range.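

In this assay, placing pyridin-2-yl where pyrimidin-2-yl stood on the amine nitrogen in a ring gives a 1.6-fold higher number from compound 3 to compound 4 (0.20 log units; within the scatter), a step that cannot on its own be told apart from repeat scatter. Set beside the earlier example of the same change, this step gives no sign that the size of the effect depends on the core: the same change on two cores in this assay, a 2.5-fold higher number (0.40 log units; beyond the scatter) from compound 2 to compound 1 and a 1.6-fold higher number (0.20 log units; within the scatter) from compound 3 to compound 4, 1.6-fold (0.20 log units) apart, within the scatter of two such steps. Within the data shown here, this supports carrying the change between these two cores as a working estimate, but it does not fix a single size for the step, since only one of the two steps lies beyond the scatter, and two pairs say nothing about how the change would behave on any other core.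

The compounds shown leave open whether the same comparison would hold with a longer chain between the amide carbonyl and the ring nitrogen, or with a chloro or methoxy group in place of the methyl group on the shared core. They also leave open how the change would behave with a carboxylic acid or an amine added to either core, as only these two pairs bear on it.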